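This account rests on a few compounds, and the source may have more. Where it says the series, first, only, none or still open, it means among the compounds named here.

Measured compounds:
- compound 1 `O=C(NOCc1ccccc1Cl)c1cn(-c2ccccc2)nc1-c1ccccc1` gives 7410 nM
- compound 2 `Cc1ccc(-c2nn(-c3ccccc3)cc2C(=O)NOCc2ccccc2Cl)cc1` gives 2640 nM
- compound 3 `O=C(NOCc1ccccc1)c1cn(-c2ccccc2)nc1-c1ccc(F)cc1` gives 15300 nM

These three share one core and were tested in a functional assay on MCF7 cells (Homo sapiens) for antiproliferative activity, read by MTT assay, with a stated time of 48 h, in the presence of a further agent that is not named here; on this read-out lower numbers stand for stronger inhibition of growth and higher numbers for weaker inhibition of growth. Compound 3 stands at the highest number of the three: compound 1 sits nearest to it, and compound 2 lies furthest away. For the measured compounds named here, the only single-place step measured so far is a 2.8-fold lower number from compound 1 to compound 2 (0.45 log units; beyond the scatter), a change on the phenyl ring rather than on the benzyl part.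

Compound 4 `O=C(NOCc1ccccc1Cl)c1cn(-c2ccccc2)nc1-c1ccc(F)cc1` arises from compound 3 by chloro in place of hydrogen on an aromatic carbon. Going by the values given here, no measured step bears directly on this change: compound 1 also carries the 2-chlorobenzyl group, but it differs from compound 3 in two places, so its numbers can only be read alongside those of compound 3 without assigning the difference to either change. The expectation therefore rests on the values of compound 1 and compound 3, and only a modest step toward a lower number is expected, as a 1.7-fold lower number from compound 3 to compound 4 (0.23 log units; within the scatter). Compound 4 is expected to give 9000 nM, within a range from 4000 nM to 20000 nM.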

Compound 4, concentration for 50% growth inhibition: 11400 nM
Beside the measured number, compound 4's estimate is 1.3-fold (0.10 log units) below it; the range from low to high includes it.
By their numbers in this assay, from the lowest: compound 2; then compounds 1, 4 and 3 (each within the scatter of the next, the first and the last beyond it).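

In this assay the first direct test of benzyl to 2-chlorobenzyl gives a 1.3-fold lower number from compound 3 to compound 4 (0.13 log units; within the scatter) and so shows no change that can be told from the scatter. With the 2-chlorobenzyl group held fixed, fluoro in place of hydrogen gives a 1.5-fold higher number from compound 1 to compound 4 (0.19 log units; within the scatter) and also stays within the scatter, whereas fluoro in place of methyl gives a 4.3-fold higher number from compound 2 to compound 4 (0.64 log units; beyond the scatter) and goes beyond it, so each single-place step beyond the scatter here involves the methyl group of compound 2. Nothing available explains these differences in step size.

Going by these compounds, it remains open whether chloro would have a larger effect with methyl in place of fluoro on the other ring. On these data alone, it also remains open how a methoxy group or an amine would act in place of chloro on the benzyl part.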